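The compounds below may be only part of what the source reports. "The series", "measured", "known", "first", "only" and "open" are said of these compounds alone.

In a functional assay on MCF7 cells (Homo sapiens) for inhibition, read by sulforhodamine B assay, with a stated time of 48 h (on this read-out lower numbers stand for stronger inhibition of growth and higher numbers for weaker inhibition of growth), compound 1 (`c1cc(NC2=NCCO2)cc(OC2CCCCC2)c1`) gives 15900 nM and compound 2 (`O=C(CCl)NC(=O)Nc1cccc(OC2CCCCC2)c1`) gives 6300 nM, the lower of the two numbers shown. Compound 3 (`O=C(CCl)NC(=O)Nc1cccc(OCc2ccccc2)c1`) carries benzyl in place of cyclohexyl on an oxygen on an aromatic ring. Going by the values given here, the only measured step, a 2.5-fold lower number from compound 1 to compound 2 (0.40 log units; beyond the scatter), is modest and lies beyond the scatter, but it changes the group on a nitrogen on an aromatic ring and keeps cyclohexyl, so it bears on this change only indirectly. Among the compounds with values here, no measured pair shows what an exchange of the group on the oxygen does. No step beyond the scatter is therefore expected in this assay, and neither direction is favoured. The expected step is a 1.1-fold lower number from compound 2 to compound 3 (0.02 log units; within the scatter). For compound 3 the estimated value is 6000 nM, with an expected range from 2500 nM to 14000 nM.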

Compound 3, concentration for 50% growth inhibition: 6200 nM
Beside the measured number, compound 3's estimate is 1.0-fold (0.01 log units) below it; the measured number falls inside the stated range.
By their numbers in this assay, from the lowest: compounds 3 and 2 (each within the scatter of the next); then compound 1.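

In this assay, the exchange on an oxygen on an aromatic ring gives a 1.0-fold lower number from compound 2 to compound 3 (0.01 log units; within the scatter), which lies within the scatter. Going by these compounds alone, this is the first measured change at this position, and it shows that benzyl can take the place of cyclohexyl with no change beyond the scatter, even though an aromatic ring of carbon only replaces a non-aromatic one. Nothing available explains why the two groups read alike.

The compounds shown leave open whether a group of another kind on this oxygen, such as a small methyl, a longer phenethyl chain, a piperidine amine or a carboxylic acid, would move the number beyond the scatter. They also leave open whether benzyl would behave in the same way on the core of compound 1.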